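The source may hold more compounds than are shown below. What is called first, only, known or untested is meant among the compounds shown, and "the series" means these compounds.

Compound 1 `COc1ccc(N(C)c2nc(C)nc3ccccc23)cc1C(=O)OCCC[Se]C#N` – 1140 nM
Compound 2 `COc1ccc(N(C)c2nc(C)nc3ccccc23)cc1C(=O)OCCCC[Se]C#N` – 1020 nM

Both numbers come from a functional assay on RKO cells (Homo sapiens) for inhibition, read by MTT assay, with a stated time of 48 h (on this read-out lower numbers stand for stronger inhibition and higher numbers for weaker inhibition), and differ only within the usual scatter of repeated measurements, so compound 2 stands level with compound 1 on this read-out.

Compound 3 `COc1ccc(N(C)c2nc(C)nc3ccccc23)cc1OCC[Se]C#N` keeps the shared core but alters the side arm. The change from compound 2 is a group of 6 heavy atoms (3 carbon, 1 nitrogen, 1 oxygen, 1 selenium; no ring) in place of a group of 10 heavy atoms (6 carbon, 1 nitrogen, 2 oxygen, 1 selenium; no ring), on an aromatic carbon, and the new group sits ortho to a methoxy group. The carbonyl of the old arm is gone, and the selenium and nitrile remain.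

Going by the values given here, only one measured step bears on this: a 1.1-fold lower number from compound 1 to compound 2 (0.05 log units; within the scatter), a change confined to the chain. Among the compounds with values here, that step is small, but it is a much narrower change, and no measured compound lacks the carbonyl. The data therefore give no direction, so no step beyond the scatter is expected, though with real uncertainty. The expected change is a 1.0-fold lower number from compound 2 to compound 3 (0.01 log units; within the scatter), an estimate resting on the two measured values. For compound 3 the estimated value is 1000 nM, with an expected range from 350 nM to 3000 nM in this assay.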

Compound 3, half-maximal inhibitory concentration: 27 nM
Estimate against measurement, compound 3: 37-fold (1.57 log units) above; measured number outside the range, below it.
By their numbers in this assay, from the lowest: compound 3; then compounds 2 and 1 (each within the scatter of the next).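

In this assay, compound 1 and compound 2, whose chains differ in length, stand level, so the chain length of the carbonyl-bearing arm showed little. Replacing that arm on the aromatic carbon is another matter, giving a 38-fold lower number from compound 2 to compound 3 (1.58 log units; beyond the scatter) and a 42-fold lower number from compound 1 to compound 3 (1.63 log units; beyond the scatter), so the number at this position can respond strongly to the group it carries, even with the selenium and the nitrile present in all three compounds. Nothing measured here accounts for the size of this step.

The change to compound 3 removes the carbonyl, alters how the arm joins the aromatic carbon and shortens the arm all at once, so the compounds shown cannot say which of these matters, or whether it takes all of them together. A longer chain on the oxygen of compound 3 would test the length of the arm alone, a short arm that keeps the carbonyl would test the carbonyl, and sulfur in place of the selenium would ask whether the selenium is needed at all.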